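The source may hold more compounds than are shown below. What is called first, only, known or untested is meant among the compounds shown, and "the series" means these compounds.

In an ADME assay (liver) for metabolic stability, with Liver microsome (Homo sapiens) as the target, read by LC-MS, using microsomes, with a stated time of 30 min, tested at 4 uM (a lower number here means that less of the compound is left, a higher number that more of the compound is left), compound 1 (`Cc1nc(N2CCN(C)CC2)c2nc(-c3cccc(Cl)c3)n(C3CCOCC3)c2n1`) gives 25% and compound 2 (`COc1ccccc1-c1nc2c(N3CCN(C)CC3)nc(C)nc2n1C1CCOCC1`) gives 22%, while compound 3 (`Cc1nc(N2CCN(C)CC2)c2nc(-c3ccccc3F)n(C3CCOCC3)c2n1`) gives 10% as the lowest of the three numbers. Compound 4 (`COc1ccc(-c2nc3c(N4CCN(C)CC4)nc(C)nc3n2C2CCOCC2)c(C)c1`) has 4-methoxy-2-methylphenyl in place of 2-fluorophenyl on an aromatic carbon. The nearest measured guide is the change from methoxy to fluoro (a number 12 percentage points lower from compound 2 to compound 3 (beyond the scatter)), which is modest and beyond the scatter. The step (a number 15 percentage points lower from compound 1 to compound 3 (beyond the scatter)) is also modest, while the other one (a number 3 percentage points lower from compound 1 to compound 2 (within the scatter)) stays within the scatter. For the measured compounds named here, no measured compound carries the 4-methoxy-2-methylphenyl group, so the reading rests on compound 2 with its methoxy group at 22% alone. Only a small rise is expected, and the estimated step (a number 5 percentage points higher from compound 3 to compound 4 (within the scatter)) stays within the scatter. Compound 4 is estimated at 15% with an expected range from 5% to 30% in this assay.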

Compound 4, percent of the compound remaining: 21%
Estimate against measurement, compound 4: 6 percentage points below, within the range that was stated.
By their numbers in this assay, from the lowest: compound 3; then compounds 4, 2 and 1 (each within the scatter of the next).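

In this assay, 4-methoxy-2-methylphenyl on the shared core gives a modest rise over 2-fluorophenyl, with a number 11 percentage points higher from compound 3 to compound 4 (beyond the scatter) as the step. Against the other two aryl groups, the steps of a number 1 percentage points lower from compound 2 to compound 4 (within the scatter) and a number 4 percentage points lower from compound 1 to compound 4 (within the scatter) show no separation. Among the four aryl groups, only 2-fluorophenyl therefore stands apart from the rest.

Going by these compounds, how an amine or a carboxylic acid on this phenyl ring would read remains open, as does any replacement of the oxan-4-yl group. No available evidence explains why 2-fluorophenyl stands apart.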